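A few compounds are considered here, and "the series" means these few. Any claim that something is new, unique, unknown or untested is made for them only; others in the source may bear on it.

Working notes on a series of three measured compounds and one awaiting measurement. The read-out throughout is a functional assay on HeLa cells (Homo sapiens) for cytotoxicity, read by MTT assay, with a stated time of 48 h; on this read-out lower numbers stand for stronger inhibition and higher numbers for weaker inhibition. Compound 1 `COc1cc(C(C2=C(O)C(=O)c3ccccc3C2=O)c2c[nH]c3ccc(Br)cc23)cc(OC)c1OC` gives 9710 nM in this assay. Compound 3 `O=C1C(O)=C(C(c2ccccc2)c2c(-c3ccccc3)[nH]c3ccccc23)C(=O)c2ccccc21` gives 18800 nM. Compound 2 `COc1ccccc1C(C1=C(O)C(=O)c2ccccc2C1=O)c1c[nH]c2ccccc12` gives 128000 nM, the highest of the three numbers; its gap to compound 3 and its larger gap to compound 1 both lie beyond the usual scatter, so compound 2 is the weakest of the three on this read-out.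

Compound 4 `COc1ccc(C(C2=C(O)C(=O)c3ccccc3C2=O)c2c[nH]c3ccccc23)cc1Br` has not yet been measured. It differs from compound 2 in one place: 3-bromo-4-methoxyphenyl in place of 2-methoxyphenyl on a saturated chain carbon bound to an aromatic carbon and a double-bonded ring carbon. Going by the values given here, no measured pair differs in only that place, so no directly comparable step is available. Compound 1 and compound 3 show that other substitution patterns on the shared core reach lower numbers than compound 2, but neither isolates the change at hand.

For compound 4 the expectation is a move toward a lower number, of a size that may or may not clear the scatter, a 3.7-fold lower number from compound 2 to compound 4 (0.56 log units; beyond the scatter). Compound 4 is accordingly estimated at 35000 nM, with a range from 8000 nM to 130000 nM.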

Compound 4, half-maximal inhibitory concentration: 7320 nM
Compound 4: middle estimate off by 4.8-fold (0.68 log units), on the high side; measured number outside the range, below it.
By their numbers in this assay, from the lowest: compounds 4, 1 and 3 (each within the scatter of the next, the first and the last beyond it); then compound 2.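

In this assay, going by these compounds alone, putting 3-bromo-4-methoxyphenyl in place of 2-methoxyphenyl on a saturated chain carbon bound to an aromatic carbon and a double-bonded ring carbon gives a 17-fold lower number from compound 2 to compound 4 (1.24 log units; beyond the scatter) as the first step that can be read directly. It shows that a change at this place alone, with the rest of compound 2 kept, moves the number well beyond the scatter. Nothing measured here bears on the origin of this step.

The step joins two differences, the added bromine and the changed placement of the methoxy group, and the compounds shown do not divide them. Also open, as far as these compounds go, is how 4-methoxyphenyl, 3-bromophenyl or 3-chloro-4-methoxyphenyl would read at this place.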